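The compounds below may be only part of what the source reports. "The series", "measured", "known", "first", "only" and "open" are said of these compounds alone.

Compound 3 `CCc1cc(Cl)cc2nc(N3CCN(C)CC3)oc12` is the stronger of the two compounds that return a number in a functional assay on ileum (strain Hartley) for agonist activity at 5-hydroxytryptamine receptor 3A (Cavia porcellus) (on this read-out higher numbers stand for higher potency (the scale is a negative logarithm) and lower numbers for lower potency), where compound 3 gives 6.82. Its nearest neighbour is compound 1 `Cc1cccc2nc(N3CCN(C)CC3)oc12`, which in this assay gives 5.48, a lower value, and the gap between the two lies beyond the scatter. Compound 2 `CC(C)c1cccc2nc(N3CCN(C)CC3)oc12` sits at a limit of this assay and not at a number, since compound 2 gives < 4 (the limit of < 4 in this assay, at which 1 of the 3 values shown sits).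

Going by the values given here, the one measured step, a number at least 1.48 log units lower from compound 1 to compound 2 (beyond the scatter), concerns the alkyl group on the shared core and says nothing about the chloro substituent. Compound 4 `CCc1cccc2nc(N3CCN(C)CC3)oc12` differs from compound 3 by hydrogen in place of chloro on an aromatic carbon. Among the compounds with values here, no measured pair isolates this change, so the expectation rests on the span between compound 3 and compound 1 and on the loss of a heavy atom from the ring.

Removing the chloro is expected to cost potency in this assay, and the step from compound 3 to compound 4 is estimated as a number 1.12 log units lower from compound 3 to compound 4 (beyond the scatter). Compound 4 is therefore expected to give about 5.7 in this assay, with the estimate ranging from 4.9 to 6.5.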

Compound 4, negative logarithm of the half-maximal effective concentration: 5.48
Estimate against measurement, compound 4: 0.22 log units above, within the range that was stated.
By their numbers in this assay, from the lowest: compounds 1 and 4 (each within the scatter of the next); then compound 3. At a limit, below all of these: compound 2.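

With chloro now isolated as a single change on the shared core, its contribution can be read directly: on the aromatic carbon meta to an ethyl group, hydrogen in place of chloro gives a number 1.34 log units lower from compound 3 to compound 4 (beyond the scatter) in this assay and so accounts for the lead of compound 3 over the compound without chlorine. The alkyl group can now be read as well, since methyl in place of hydrogen on the chain gives no change at the digits printed from compound 1 to compound 4 (within the scatter) and a chain extended from methyl to ethyl alone therefore shows no separation, whereas the change to the branched isopropyl group, read here in the other direction, gives a number at least 1.48 log units higher from compound 2 to compound 4 (beyond the scatter) as a sharp difference among alkyl groups. That last step has only one firm end, as compound 2 stands at a limit of the assay and not at a number: the limit of < 4 in this assay, at which 1 of the 4 values shown sits.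

Going by these compounds, what fluoro, bromo, methoxy or nitrile would give in place of chloro on this aromatic carbon stays open, so it cannot be said whether the gain is particular to chlorine. Also open is whether chloro would bring a similar step alongside methyl or a longer propyl chain, as it is shown here only with ethyl.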